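Ester on a pyrazole core: from 4-ethylphenyl to thymyl

The source may report more compounds than this note shows. Statements on the series, on what has been measured and on what is new or still open speak of the compounds shown alone.

Measured compounds:
compound 1, `O=C(NCc1ccccc1)c1cn(-c2ccccc2)nc1-c1ccncc1` — in a functional assay on MCF7 cells (Homo sapiens) for cytotoxicity, read by MTT assay, with a stated time of 48 h (on this read-out higher numbers stand for weaker inhibition and lower numbers for stronger inhibition), compound 1 gives > 100000 nM
compound 2, `CCc1ccc(OC(=O)c2cn(-c3ccccc3)nc2-c2ccncc2)cc1` — in this assay compound 2 gives "nd(insoluble)" (no result reported)

Compound 1 carries an amide on the shared core. Its value in this assay is a limit of the measurement, not a number. Compound 2 replaces that amide with an ester of 4-ethylphenol; for compound 2 no number was obtained in this assay at all. So compound 2 stands nowhere on a numerical scale: the only further entry shown for this series is the limit of > 100000 nM in this assay, at which 1 of the 2 values shown sits, and compound 2 itself has no value to compare with it.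

Compound 3, `Cc1ccc(C(C)C)c(OC(=O)c2cn(-c3ccccc3)nc2-c2ccncc2)c1`, keeps the same core and ester link. The change is 2-isopropyl-5-methylphenyl in place of 4-ethylphenyl on an oxygen next to a carbonyl group.

Among the measured compounds shown here, with no measured step between any two compounds, no size of step in this assay can be read off, and no direction can be claimed beyond the scatter. The expectation for compound 3 is therefore estimated only from the weak picture of the pair: compound 3 is expected at about 80000 nM, within a range from 20000 nM to 200000 nM, with a real chance that again only a limit or no number results.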

Compound 3, half-maximal inhibitory concentration: > 100000 nM
Compound 3 ended at the assay's limit; the forecaster's own chance of this, stated with the estimate: 65%; middle value at least 1.2-fold (0.09 log units) from the limit.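

In this assay compound 3 gives > 100000 nM, which is a limit of the measurement and not a number. Compound 2 has no reported result, and no step can be read between compound 2 and compound 3. The compounds shown leave open whether an amide or ester on the shared core can give a measured number, and the series so far rests on one entry: the limit of > 100000 nM in this assay, at which 2 of the 3 values shown sit.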